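A few compounds are considered here, and "the series" means these few. Any claim that something is new, unique, unknown or untested is made for them only; others in the source may bear on it.

Values so far in an ADME assay on Vero cells (Chlorocebus sabaeus) for cytotoxicity, read by MTT assay, with a stated time of 72 h (a lower number here means that less compound is tolerated, a higher number that more compound is tolerated), are these:
compound 1 `CC1(C)C=Cc2c(ccc(C(=O)/C=C/c3ccc(F)cc3)c2O)O1` gives 158000 nM
compound 2 `CC1(C)C=Cc2c(ccc(C(=O)/C=C/c3ccc(Cl)cc3Cl)c2O)O1` gives 131000 nM

Compound 1 has only compound 2 for comparison, and a 1.2-fold lower number from compound 1 to compound 2 (0.08 log units; within the scatter) leaves the two level. Compound 3 `CC1(C)C=Cc2c(ccc(C(=O)/C=C/c3ccc([N+](=O)[O-])cc3)c2O)O1` is still unmeasured and differs from compound 1 as follows: nitro in place of fluoro on an aromatic carbon in short, nitro in place of fluoro on an aromatic carbon, para to a large group. Among the compounds with values here, the one measured step that bears on this is 2,4-dichlorophenyl in place of 4-fluorophenyl. Within the data shown here, no nitro compound has a value yet, so the guide is thin. Because of a 1.2-fold lower number from compound 1 to compound 2 (0.08 log units; within the scatter) at that group, no step beyond the scatter is expected in this assay for the new substituent. Compound 3 is estimated at 120000 nM with an expected range from 50000 nM to 260000 nM in this measurement. The expected 1.3-fold lower number from compound 1 to compound 3 (0.12 log units; within the scatter) stays within the scatter of repeats.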

Compound 3, half-maximal cytotoxic concentration: 106000 nM
Compound 3: the middle estimate sits 1.1-fold (0.05 log units) above what was measured; measured number inside the range.
By their numbers in this assay, from the lowest: compounds 3, 2 and 1 (each within the scatter of the next).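

In this assay nitro in place of fluoro on an aromatic carbon, para to a large group, gives a 1.5-fold lower number from compound 1 to compound 3 (0.17 log units; within the scatter) and so brings no step beyond the scatter, even though three heavy atoms enter where one leaves and hydrogen-bond acceptors are added. Alongside a 1.2-fold lower number from compound 1 to compound 2 (0.08 log units; within the scatter) this makes two replacements on this six-membered aromatic ring, and neither step leaves the scatter in this measurement. No measured property of these groups accompanies the values, so nothing can be said about what lies behind this flat result.

Still open, going by these compounds, is whether an amine, a carboxylic acid or a methoxy group at this position would give a step beyond the scatter. Also open, on these data alone, is whether the numbers stay level when the change is made elsewhere on the shared core, for example at the hydroxyl group or the carbonyl.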